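This account rests on a few compounds, and the source may have more. Where it says the series, first, only, none or still open, it means among the compounds named here.

Among the measured compounds shown here, compound 2 `COc1ccc(C(=O)Nc2cnccn2)cc1OC1CCCC1` holds the lower of the two numbers so far in an assay on isolated protein for inhibition of phosphodiesterase 4A (Sus scrofa) (a lower number here means a stronger inhibitor, a higher number a weaker inhibitor), with 250 nM; compound 1 `COc1ccc(C(=O)Nc2ccccc2SC)cc1OC1CCCC1` gives 1200 nM in this assay. For the measured compounds named here, the one measured step, a 4.8-fold lower number from compound 1 to compound 2 (0.68 log units; beyond the scatter), came from exchanging the group on the amide-type nitrogen. Compound 3 `COc1ccc(C(=O)Nc2nccs2)cc1OC1CCCC1` carries the change (1,3-thiazol-2-yl in place of pyrazin-2-yl on an amide-type nitrogen). Going by the values given here, only that step bears on it, and it concerned a different pair of groups on the same nitrogen, so the expectation for compound 3 is a step of a 1.2-fold higher number from compound 2 to compound 3 (0.08 log units; within the scatter), near the scatter, with compound 3 estimated at 300 nM, in the range 100 nM to 900 nM.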

Compound 3, half-maximal inhibitory concentration: 6500 nM
Compound 3: the middle estimate sits 22-fold (1.34 log units) below what was measured, and the stated range ends below it.
By their numbers in this assay, from the lowest: compound 2; then compound 1; then compound 3.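

Among the compounds shown here, the group on the amide-type nitrogen matters more in this assay than the earlier step showed: replacing pyrazin-2-yl with 1,3-thiazol-2-yl, both aromatic rings with hetero atoms, gives a 26-fold higher number from compound 2 to compound 3 (1.41 log units; beyond the scatter) and is the largest step so far. Compound 3 also falls behind the non-heteroaromatic group, with a 5.4-fold higher number from compound 1 to compound 3 (0.73 log units; beyond the scatter), so a ring with hetero atoms on this nitrogen does not by itself give the lower number. Nothing available explains this loss.

Open, on these data alone, is where pyridin-2-yl or plain phenyl on this nitrogen would fall, and whether a methyl group on the 1,3-thiazol-2-yl ring would shift the number.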